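Chain extension on a phenol ester and its carbonate analogue

The source may report more compounds than this note shows. Statements on the series, on what has been measured and on what is new or still open speak of the compounds shown alone.

Compound 1, `COCCOCCOCCOCC(=O)Oc1c(C(C)C)cccc1C(C)C`, is an ester of a phenol carrying two isopropyl groups, joined to a chain of ether links. In an ADME assay on A549 cells (Homo sapiens) for cytotoxicity, read by MTT assay, with a stated time of 24 h (a higher number here means that more compound is needed for the effect, a lower number that less compound is needed), compound 1 gives 740000 nM. Compound 2, `COCCOCCOCCOCCOCC(=O)Oc1c(C(C)C)cccc1C(C)C`, carries one more ether unit on that chain; the change is methoxymethyl in place of hydrogen on a saturated chain carbon bound to an oxygen on a saturated carbon. In this assay compound 2 gives 630000 nM, so the step of a 1.2-fold lower number from compound 1 to compound 2 (0.07 log units; within the scatter) is small.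

Compound 3, `COCCOCCOCCOC(=O)Oc1c(C(C)C)cccc1C(C)C`, has a carbonate instead of the ester between the phenol and the chain; the difference between the core of compound 3 and the core of compound 1 is not broken down here. In this assay compound 3 gives 2130000 nM, the highest of the three measured numbers, so more of it is needed for the effect than of compound 1 or compound 2.

Compound 4, `COCCOCCOCCOCCOC(=O)Oc1c(C(C)C)cccc1C(C)C`, is not yet measured. Its relation to compound 3 is the same change as that from compound 1 to compound 2, namely (methoxymethyl in place of hydrogen on a saturated chain carbon bound to an oxygen on a saturated carbon). Because the measured step of a 1.2-fold lower number from compound 1 to compound 2 (0.07 log units; within the scatter) stayed within the scatter, the expected step of a 1.2-fold lower number from compound 3 to compound 4 (0.07 log units; within the scatter) is likewise small. Compound 4 is therefore estimated at 1800000 nM in this assay, with an expected range from 900000 nM to 3600000 nM, resting only on that one prior step and on the value of compound 3.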

Compound 4, half-maximal effective concentration: 1360000 nM
Beside the measured number, compound 4's estimate is 1.3-fold (0.12 log units) above it; the measured number falls inside the stated range.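

In this assay, methoxymethyl in place of hydrogen on the chain of the core of compound 3 gives a 1.6-fold lower number from compound 3 to compound 4 (0.19 log units; within the scatter), so this step, like the earlier one, is small. Set side by side, the two steps agree: the same change on two cores in this assay, a 1.2-fold lower number (0.07 log units; within the scatter) from compound 1 to compound 2 and a 1.6-fold lower number (0.19 log units; within the scatter) from compound 3 to compound 4, 1.3-fold (0.12 log units) apart, within the scatter of two such steps. In these two pairs the change therefore carries from the core of compound 1 to the core of compound 3 with little effect on the number, but this shows only that one added chain unit stays within the scatter on both cores, and two small steps cannot reveal a shared trend or show that the same would hold on any other core.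

The compounds shown leave open what a much longer chain would do, and whether the small steps would persist if the methoxy group at the end of the chain gave way to a hydroxyl group, an amine or a carboxylic acid. They also leave open how an amide link would compare with the ester and carbonate links, and whether the same small steps would appear in a cell line other than the one used here.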